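The source may report more compounds than this note shows. Statements on the series, on what has been measured and on what is new or still open speak of the compounds shown alone.

In a physicochemical assay for lipophilicity (a higher number here means a more lipophilic compound, a lower number a more polar compound), compound 1 (`Nc1ccccc1NC(=O)c1ccc(CSC2=N[C@@H](c3ccccc3)CN2)cc1`) reads 4.31 and compound 2 (`Nc1ccccc1NC(=O)c1ccc(CNC2=N[C@@H](c3ccccc3)CN2)cc1`) reads 3.46. Compound 3 (`Nc1ccccc1NC(=O)c1ccc(CSC2=N[C@@H](Cc3ccccc3)CO2)cc1`) reads 5.67, the highest of the three numbers and beyond the scatter above both compound 1 and compound 2.

The next compound to be measured is compound 4 (`Nc1ccccc1NC(=O)c1ccc(CSC2=N[C@@H](c3cccnc3)CO2)cc1`). Relative to compound 3, it has pyridin-3-yl in place of benzyl on a saturated ring carbon, in the five-membered non-aromatic ring with 1 nitrogen and 1 oxygen: pyridin-3-yl in place of benzyl on a saturated ring carbon. An aromatic ring of carbon only gives way to an aromatic ring with a hetero atom, and a hydrogen-bond acceptor enters.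

Within the data shown here, no pair of measured compounds isolates this change, so the series offers no direct precedent for its size. The expectation rests on the structural change alone, and compound 3 sits at the top of the measured numbers, leaving ample room for a fall. A clear decrease is expected, well beyond the scatter, with an estimated step of a number 1.67 log units lower from compound 3 to compound 4 (beyond the scatter). For compound 4, the expected value in this assay is 4, within an estimated range of 3.5 to 4.5.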

Compound 4, partition coefficient: 3.32
Compound 4: middle estimate off by 0.68 log units, on the high side; the measured number lies below the stated range.
By their numbers in this assay, from the lowest: compounds 4 and 2 (each within the scatter of the next); then compound 1; then compound 3.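

The pair gives the series its first one-place comparison: in this assay, replacing benzyl with pyridin-3-yl on the saturated ring carbon next to the ring nitrogen gives a number 2.35 log units lower from compound 3 to compound 4 (beyond the scatter), a large step. This position is therefore far from indifferent to the group it carries, at least for this one change in the five-membered non-aromatic ring with 1 nitrogen and 1 oxygen. The change is also not a single variable, since the entering group differs from benzyl in its ring, its hydrogen-bond acceptor count and its heavy-atom count, and no available information gives a reason for the size of the step.

Going by these compounds, how the step divides among those differences remains open; phenyl or pyridin-3-ylmethyl on the same carbon would each share one feature with benzyl and one with pyridin-3-yl, and so would help to separate them. Also unresolved is whether the same swap would give a step of similar size in the core of compound 1, where the ring holds two nitrogens, or with pyridin-2-yl or pyridin-4-yl in its place.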